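Triazole in place of phenylurea on the pyrrolidine-bearing series

The source may report more compounds than this note shows. Statements on the series, on what has been measured and on what is new or still open speak of the compounds shown alone.

Two members of this set have been read in an ADME assay on microsomes from liver (Mus musculus) for metabolic stability, read by LC-MS, with NADPH named in the record, with a stated time of 60 min, tested at 1 uM, in the absence of a further agent; on this read-out higher numbers stand for a more stable compound and lower numbers for a less stable compound. Compound 1 `COc1ccc(-c2scc3c(N4CC[C@@H](NC(C)=O)C4)nc(C)nc23)cc1OC` sits at the limit of that assay, > 95%, a ceiling rather than a number. Compound 2 `COc1ccc(-c2c(C)nc3c(N4CC[C@@H](NC(=O)Nc5ccccc5)C4)cc(C)nn23)cc1OC` likewise reaches only the limit, > 95%, in this assay. Thus both values known so far rest at the same limit (the limit of > 95% in this assay, at which 2 of the 2 values shown sit), and no measured step between them can be set out. Compound 3 `COc1ccc(-c2c(C)nc3c(N4CC[C@@H](n5cc(-c6ccccc6)nn5)C4)cc(C)nn23)cc1OC` differs from compound 2 by 4-phenyl-1H-1,2,3-triazol-1-yl in place of (phenylcarbamoyl)amino on a saturated ring carbon. Any step in this assay is expected to stay within the scatter or to drift slightly downward, the expected step being a number at least 5 percentage points lower from compound 2 to compound 3 (that floor lies within the scatter). For compound 3 a value of 90% is estimated, within 70% to 98%.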

Compound 3, percent of the compound remaining: "unstable" (no number reported)
No number was reported for compound 3; the estimate stays without a comparison.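

Among these compounds, compound 3 is recorded only as "unstable" in this assay, without a number, and no step from compound 2 to compound 3 can be read. The compounds shown leave open how large any difference between these two compounds is.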